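A few compounds are considered here, and "the series" means these few. Any claim that something is new, unique, unknown or untested is made for them only; others in the source may bear on it.

Compound 1 `Cc1cc(NC(=O)Nc2ccc(C(C)(C)C)cc2)c2ccccc2n1` is one of three compounds on a shared core that have been measured in an ADME assay on BJ cells (Homo sapiens) for cytotoxicity, with a stated time of 72 h; a higher number here means that more compound is needed for the effect, a lower number that less compound is needed. In this assay compound 1 gives 20000 nM, the lowest of the two numbers available. Compound 2 `Cc1cc(NC(=O)Nc2ccc(Cl)c(Cl)c2)c2ccccc2n1` gives 23000 nM in this assay, a number that sits within the scatter of the result for compound 1, so the two cannot be told apart. Compound 3 `Cc1cc(NC(=O)Nc2cc(Cl)cc(Cl)c2)c2ccccc2n1` in this assay gives only a limit, > 25000 nM, and no number. That is the limit of > 25000 nM in this assay, at which 1 of the 3 values shown sits. Going by the values given here, no pair of these three differs in a single place, so no single step within the measured set can be read off.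

Compound 4 `Cc1cc(NC(=O)Nc2ccc(O)cc2)c2ccccc2n1` has not yet been measured in this assay. It differs from compound 1 in one place: hydroxy in place of tert-butyl on an aromatic carbon. Among the compounds with values here, none of the measured compounds carries a hydroxy group, so the measured values give no step that bears directly on this change. With all three measured results sitting close together, compound 4 is expected to stay in the same region, and the step of a 1.2-fold higher number from compound 1 to compound 4 (0.08 log units; within the scatter) is expected to be small, within the scatter or a modest shift towards a higher number. In this assay compound 4 is therefore estimated at 24000 nM, between 12000 nM and 50000 nM, with a real chance that only a limit is returned.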

Compound 4, half-maximal effective concentration: > 25000 nM
Compound 4: no number, only a limit; the forecaster's own chance of this, stated with the estimate: 50%; middle value at least 1.0-fold (0.01 log units) from the limit.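

In this assay compound 4 returns a limit and not a number, which gives this position its first reading with a group other than tert-butyl, though that reading has a floor and no upper end. From the compounds shown here alone, the change of tert-butyl to hydroxy on an aromatic carbon, para to a large group, is a step of an at least 1.2-fold higher number from compound 1 to compound 4 (0.09 log units; that floor lies within the scatter), and this shows that a much smaller group with a hydrogen-bond donor in place of the four-carbon group does not bring the number down, while the true size of the step stays unknown. The result also adds a second compound to those that give no number, which narrows what can be compared within this set: the limit of > 25000 nM in this assay, at which 2 of the 4 values shown sit.

The compounds shown leave open what an amine, a carboxylic acid or a methoxy group would give at this position, and whether any replacement of tert-butyl there would produce a step clearly beyond the scatter. They also leave open how far past its limit compound 4 actually lies, and whether a hydroxy group would give the same kind of result on the dichloro ring of compound 2.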